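The compounds below may be only part of what the source reports. "The series", "measured", "known", "first", "only" and "open" are said of these compounds alone.

Measured compounds:
compound 1, `CC1=CC[C@H](C(C)(C)NC(=S)NN)CC1`, > 100000 nM in a functional assay on 786-0 cells (Homo sapiens) for inhibition, read by sulforhodamine B assay, with a stated time of 48 h; a lower number here means a stronger inhibitor of growth, a higher number a weaker inhibitor of growth
compound 2, `CC1=CC[C@H](C(C)(C)NC(=S)N/N=C/c2ccccc2)CC1`, 9900 nM in this assay

The series starts from a thiosemicarbazide and moves to its benzylidene condensation product. In this assay compound 1 gives only a limit, > 100000 nM, not a number. For the measured compounds named here, compound 2 is the one compound with a real number in this assay, 9900 nM, so it alone gives a fixed point from which to judge a further change. Of compound 1 nothing more is known than that it sits at the limit described by the limit of > 100000 nM in this assay, at which 1 of the 2 values shown sits.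

The next compound, compound 3 with the structure `COc1ccc(/C=N/NC(=S)NC(C)(C)[C@H]2CC=C(C)CC2)cc1`, keeps the whole thiosemicarbazone of compound 2 and changes one position: methoxy in place of hydrogen on an aromatic carbon. Going by the values given here, a methoxy group on a phenyl ring of this kind is a small addition, and there is no measured pair in this set that shows what such an addition does here. The step from compound 2 to compound 3 is therefore expected to be small, as a 1.4-fold lower number from compound 2 to compound 3 (0.15 log units; within the scatter), and not beyond the usual scatter in either direction. Compound 3 is estimated at 7000 nM, within a range from 2500 nM to 20000 nM.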

Compound 3, concentration for 50% growth inhibition: 8900 nM
For compound 3 the middle estimate is 1.3-fold (0.10 log units) below the measured one; the measured number falls inside the stated range.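

Putting methoxy in place of hydrogen, on an aromatic carbon para to a large group, gives a 1.1-fold lower number from compound 2 to compound 3 (0.05 log units; within the scatter) in this assay. For the compounds shown here, this is the first comparison between two real numbers, and it shows that the phenyl to 4-methoxyphenyl change leaves compound 3 indistinguishable from compound 2 in this read-out, so this position can carry a methoxy group without a measurable loss or gain in growth inhibition. Nothing shown gives a reason for this outcome, and a single step within the scatter cannot be read as a trend of any kind.

The compounds shown leave open whether a different group at the same place, such as an amine, a carboxylic acid, a chlorine atom or a longer chain ending in an ether oxygen, would move the number beyond the scatter in either direction. They also leave open whether methoxy on another carbon of the same ring would behave as it does here, and whether changes to the shared core outside the phenyl ring would matter more than changes on it.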